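The compounds below may be only part of what the source reports. "The series", "measured", "known", "first", "only" and "open" are said of these compounds alone.

Measured compounds and their values in a functional assay on LOX IMVI cells (Homo sapiens) for cytotoxicity, read by sulforhodamine B assay, with a stated time of 48 h, tested at 1 uM; a higher number here means a weaker effect of the compound at the concentration tested, a lower number a stronger effect:

compound 1 `COc1cc(-c2cc(/C=C/C(=O)c3ccc(N)cc3)[nH]n2)cc(OC)c1OC`: 83%
compound 2 `COc1ccc(-c2cc(/C=C/C(=O)c3ccc(N)cc3)[nH]n2)cc1OC`: 96%
compound 3 `COc1ccc(-c2cc(/C=C/C(=O)c3cc(OC)c(OC)c(OC)c3)[nH]n2)cc1OC`: 78%

Among these three numbers compound 1 stands second highest. Its nearest neighbour is compound 3, whose 78% lies within the scatter of it; furthest away is compound 2, whose 96% lies beyond the scatter. Within the data shown here, the one measured step, a number 13 percentage points higher from compound 1 to compound 2 (beyond the scatter), comes from hydrogen in place of methoxy on an aromatic carbon and is modest in size.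

Compound 4 `COc1ccc(C(=O)/C=C/c2cc(-c3cc(OC)c(OC)c(OC)c3)n[nH]2)cc1` differs from compound 1 in a different place: methoxy in place of amino on an aromatic carbon. Among the measured compounds shown here, no measured step concerns this amino group, so the step from compound 1 to compound 2 bears on it only loosely. What can be said is that compound 3, which carries no amino group at all, sits within the scatter of compound 1 in this assay. No step beyond the scatter is therefore expected; the expected step is a number 2 percentage points higher from compound 1 to compound 4 (within the scatter). Compound 4 is accordingly estimated at 85%, with a range from 65% to 100%.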

Compound 4, a percentage reported as activity, at one concentration (the size of the read-out at that concentration, not a potency): 85%
The estimate for compound 4 equals the measured number at the digits printed; the measured number falls inside the stated range.
By their numbers in this assay, from the lowest: compounds 3, 1 and 4 (each within the scatter of the next); then compound 2.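

In this assay, among these compounds, the first measured step at this position gives a number 2 percentage points higher from compound 1 to compound 4 (within the scatter), and it comes from methoxy in place of amino on an aromatic carbon, para to a large group. With the rest of compound 1 held fixed, the change from 4-aminophenyl to 4-methoxyphenyl therefore gives no reading beyond the scatter, even though the hydrogen-bond donor of the amino group leaves. Nothing available here explains why this exchange makes so little difference.

From the compounds shown here alone, what a hydroxyl group, a chlorine atom or a dimethylamino group would give at this place remains open. Also open, going by these compounds, is whether amino and methoxy would still read alike on the core of compound 2, which lacks one methoxy group of compound 1, and at concentrations other than the single one tested here.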